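Alkoxy chain variation at the quaternary carbon: compound 3

The compounds below may be only part of what the source reports. "The series", "measured", "known", "first", "only" and "open" are said of these compounds alone.

compound 1 `CCCCOC1(c2ccc(Br)cc2)SC=C(C)n2c1noc2=O`: 78000 nM in a functional assay on A2780/DX3 cells (Homo sapiens) for antiproliferative activity, read by MTT assay, with a stated time of 3 days; on this read-out lower numbers stand for stronger inhibition and higher numbers for weaker inhibition
compound 2 `COC1(c2ccc(Br)cc2)SC=C(C)n2c1noc2=O`: > 100000 nM in this assay

Compound 2 stands at the edge of what this assay reports: its value of > 100000 nM is a limit of the assay, not a number, and the limit of > 100000 nM in this assay, at which 1 of the 2 values shown sits, describes where it sits. Compound 1 gives a measured number, 78000 nM. Within the data shown here, the single measured step, an at least 1.2-fold higher number from compound 1 to compound 2 (0.10 log units; that floor lies within the scatter), is read against a limit, and its floor lies within the scatter.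

Compound 3, `CC/C=C/COC1(c2ccc(Br)cc2)SC=C(C)n2c1noc2=O`, carries but-1-en-1-yl in place of hydrogen on a saturated chain carbon bound to an oxygen on a saturated carbon. Cut one bond further out, this reads methoxy to (pent-2-en-1-yl)oxy, so the change runs in the same sense as the step from compound 2 back to compound 1: a longer chain on the oxygen at this place. That step is the only guide, and it moved the number down by at least the floor shown, a floor within the scatter. A step of similar or somewhat larger size, away from the limit, is expected for an at least 1.4-fold lower number from compound 2 to compound 3 (0.15 log units; that floor lies within the scatter). Compound 3 is therefore expected near 70000 nM, with a range from 30000 nM to 150000 nM, and a real chance that only a limit is returned.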

Compound 3, half-maximal inhibitory concentration: 111000 nM
The estimate for compound 3 lay 1.6-fold (0.20 log units) below the measured number; measured number inside the range.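

In this assay, but-1-en-1-yl in place of propyl on a saturated chain carbon bound to an oxygen on a saturated carbon gives a 1.4-fold higher number from compound 1 to compound 3 (0.15 log units; within the scatter), so the two longer chains on the oxygen cannot be told apart here, although only one of them carries a double bond. Compound 3 adds a second measured number at this place, and it stays in the same high range as compound 1, so the double bond brings no readable change in this assay. Compound 2 gives > 100000 nM, which is a limit of the assay and not a number, so the steps from it cannot be read and no gain from lengthening methoxy can be sized: the limit of > 100000 nM in this assay, at which 1 of the 3 values shown sits.

Still open, from the compounds shown here alone, is whether any group on this oxygen can move the number beyond the scatter, for example a chain ending in an amine or a carboxylic acid, or a longer saturated chain. Also open, going by these compounds, is whether a phenyl ring at the end of the chain would behave as the two longer chains do here.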